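Moving a Fluorine Around the Ring in a Histamine Series

The compounds below may be only part of what the source reports. "The series", "measured", "known", "first", "only" and "open" are said of these compounds alone.

Compound 1 `Cc1nc(N)sc1CCCN/C(N)=N/C(=O)NC(C)c1cccc(F)c1` is the reference point. In an assay on membranes from Sf9 cells for displacement of a labelled ligand from histamine H2 receptor (Homo sapiens), read by scintillation counting, with a stated time of 60 min (on this read-out lower numbers stand for stronger inhibition and higher numbers for weaker inhibition), compound 1 gives 2.04 nM, the lowest of the three numbers available. The nearest neighbour on this read-out is compound 3 `Cc1nc(N)sc1CCCN/C(N)=N/C(=O)NCC(C)CCCc1ccccc1`, which in this assay gives 60.3 nM, a gap beyond the usual scatter. Furthest away is compound 2 `Cc1nc(N)sc1CCCN/C(N)=N/C(=O)Nc1ccccc1`, which in this assay gives 3160 nM, again a gap well beyond the scatter. Compound 1 thus stands clearly apart from both measured companions.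

Compound 4 `Cc1nc(N)sc1CCCN/C(N)=N/C(=O)NC(C)c1ccc(F)cc1` has not yet been measured. It differs from compound 1 in one place: 4-fluorophenyl in place of 3-fluorophenyl on a saturated chain carbon bound to an amide-type nitrogen and a saturated chain carbon. The two compounds contain the same atoms, joined differently. Among the measured compounds shown here, no measured pair in this set shows what such a change does, so the expectation rests on compound 1 alone. Moving a single fluorine to a different position on the same ring is expected to give at most a small step, not clearly beyond the scatter, and the step expected is a 1.6-fold higher number from compound 1 to compound 4 (0.20 log units; within the scatter). Compound 4 is therefore estimated at 3.2 nM, with a range from 0.8 nM to 13 nM.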

Compound 4, inhibition constant: 31.6 nM
For compound 4 the middle estimate is 9.9-fold (0.99 log units) below the measured one; the whole stated range lies below it.
By their numbers in this assay, from the lowest: compound 1; then compounds 4 and 3 (each within the scatter of the next); then compound 2.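

In this assay, 4-fluorophenyl in place of 3-fluorophenyl gives a 15-fold higher number from compound 1 to compound 4 (1.19 log units; beyond the scatter), a large step beyond the scatter, although the two compounds contain the same atoms and the group that leaves and the one that enters have identical counts of heavy atoms, donors and acceptors. The earlier values could not show this, since neither compound 2 nor compound 3 forms a single-place comparison with compound 1; this pair shows that, on this ring, the place of the fluorine alone can change the number substantially. No data at hand bear on the cause of this step.

The compounds shown include no chlorine or methoxy group on this ring and no plain phenyl on the same saturated chain carbon, so it remains open whether the fluorine improves the number in compound 1, worsens it in compound 4, or does both. Also open, as far as these compounds go, is whether the difference between the two fluorine placements would persist with a longer chain carrying the ring.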